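The compounds below may be only part of what the source reports. "The series", "measured", "known", "first", "only" and "open" are said of these compounds alone.

Compounds in hand, with a physicochemical assay for lipophilicity; on this read-out higher numbers stand for higher lipophilicity and lower numbers for lower lipophilicity:

- compound 1, `CC(/C=C/CC(C)CCCC(C)C)=C\C(=O)OC(C)C`: 7.15
- compound 2, `CC(/C=C/CC(C)CCCC(C)(C)OC=O)=C\C(=O)OC(C)C`: 5.4
- compound 3, `CSC(C)(C)CCCC(C)C/C=C/C(C)=C/C(=O)OC(C)C`: 6.77

Compound 1 has the highest of the three values. The nearest is reached by the step of a number 0.38 log units lower from compound 1 to compound 3 (beyond the scatter), the furthest by the step of a number 1.75 log units lower from compound 1 to compound 2 (beyond the scatter); the two substituted compounds themselves differ by a number 1.37 log units higher from compound 2 to compound 3 (beyond the scatter).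

Compound 4, `CSC(=O)/C=C(C)/C=C/CC(C)CCCC(C)C`, has not yet been measured. It differs from compound 1 in one place: methylsulfanyl in place of isopropoxy on a carbonyl carbon. None of the three measured steps sits on a carbonyl carbon; all three are changes on a saturated chain carbon bound to three saturated chain carbons, so they bear on the new step only loosely. The closest analogy is the entry of methylsulfanyl in compound 3, which moved the value modestly downward from compound 1, but there it replaced hydrogen, not isopropoxy. With the loss of isopropoxy weighed against the entry of methylsulfanyl, a modest fall is expected, a number 0.45 log units lower from compound 1 to compound 4 (beyond the scatter). For compound 4 the estimated value in this assay is 6.7, expected to lie between 6.1 and 7.3.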

Compound 4, partition coefficient: 7.44
The estimate for compound 4 lay 0.74 log units below the measured number, and the stated range ends below it.
By their numbers in this assay, from the lowest: compound 2; then compound 3; then compounds 1 and 4 (each within the scatter of the next).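

On a carbonyl carbon, methylsulfanyl in place of isopropoxy gives in this assay a number 0.29 log units higher from compound 1 to compound 4 (within the scatter), so this exchange of one whole group for another does not separate the two compounds on this read-out. The earlier steps shown here, all on a saturated chain carbon bound to three saturated chain carbons, each lay beyond the scatter, whereas this single step at the carbonyl carbon does not, although one step at one place sets no pattern. No measurement on these compounds offers an explanation for this result.

As far as these compounds go, whether other groups on this carbonyl carbon, such as dimethylamino or hydroxy, would also stay within the scatter of compound 1 remains open. Also open, from the compounds shown here alone, is how methylsulfanyl compares on this carbon with a smaller alkoxy group such as methoxy.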